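The source may report more compounds than this note shows. Statements on the series, on what has been measured and on what is new or still open speak of the compounds shown alone.

Three compounds built on the same core, each carrying a trifluoromethyl-bearing hydroxyphenyl group and a 2-hydroxyphenyl group, have been tested. Compound 1 `Cc1ccc(-n2nc(-c3ccc(C(F)(F)F)cc3O)nc2-c2ccccc2O)cc1` gives 94.1% in a functional assay on PC-12 cells (Rattus norvegicus) for cytotoxicity, read by MTT assay, with stated times of 2 h and 24 h, tested at 5 uM; a lower number here means a weaker effect, a higher number a stronger effect of the compound at the concentration tested. Compound 2 `CCc1ccc(-n2nc(-c3ccc(C(F)(F)F)cc3O)nc2-c2ccccc2O)cc1` gives 95.4% in this assay, and compound 3 `Oc1cc(C(F)(F)F)ccc1-c1nc(-c2ccccc2O)n(-c2cccc(Cl)c2)n1` gives 92.7% there. The number for compound 2 sits at the top of the three, but its gaps to both others are within the scatter, so no ranking of the three can be read from these readings. The single-point exchanges confirm this: a number 1.3 percentage points higher from compound 1 to compound 2 (within the scatter), a number 1.4 percentage points lower from compound 1 to compound 3 (within the scatter) and a number 2.7 percentage points lower from compound 2 to compound 3 (within the scatter).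

Compound 4 `Cc1ccc(-n2nc(-c3ccc(C(F)(F)F)cc3O)nc2-c2ccccc2O)c(C)c1` differs from compound 2 in one place, where (2,4-dimethylphenyl in place of 4-ethylphenyl on an aromatic nitrogen). The two measured exchanges of the ring on that aromatic nitrogen, from compound 1 to compound 3 and from compound 2 to compound 3, both stayed within the scatter, and the added carbon on the chain from compound 1 to compound 2 did likewise. Nothing in these data suggests a move beyond the scatter in this assay for another such exchange, so the expected step is a number 1.4 percentage points lower from compound 2 to compound 4 (within the scatter). Compound 4 is therefore estimated at 94%, within a range from 88% to 99%.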

Compound 4, a percentage reported as activity, at one concentration (the size of the read-out at that concentration, not a potency): 93.3%
Compound 4: middle estimate off by 0.7 percentage points, on the high side, within the range that was stated.
By their numbers in this assay, from the lowest: compounds 3, 4, 1 and 2 (each within the scatter of the next).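

In this assay, moving from one alkyl pattern to another on the ring at the aromatic nitrogen gives a number 2.1 percentage points lower from compound 2 to compound 4 (within the scatter), even though 4-ethylphenyl and 2,4-dimethylphenyl hold the same count of heavy atoms joined differently. The new compound also adds two further exchanges, a number 0.6 percentage points higher from compound 3 to compound 4 (within the scatter) and a number 0.8 percentage points lower from compound 1 to compound 4 (within the scatter), the second being the first case here of a methyl placed on an aromatic carbon of that ring, so a ring carrying two substituents now joins the singly substituted ones, and all of these steps stay within the scatter. No measurement is available that would explain why these readings stay so close together.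

From the compounds shown here alone, the groups on this ring so far are limited to methyl, ethyl and chloro, so it remains open whether an amine, a carboxylic acid or a longer chain such as hexyl at that place would give a step beyond the scatter. Going by these compounds, the two hydroxyl groups and the trifluoromethyl group are common to all four compounds, so what a methoxy in place of a hydroxyl would do, for example, also stays unknown.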